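The compounds below may be only part of what the source reports. "The series", "measured", "known", "first", "only" and "open" are said of these compounds alone.

Measured in an ADME assay on microsomes from liver (Homo sapiens) for metabolic stability; a higher number here means that the compound lasts longer, a lower number that the compound disappears faster:
- compound 1 `CC(C)C(c1ccc(-c2ccc3cccc(F)c3c2)[nH]c1=O)C1NC(=O)NC1=O`: 0.578 h
- compound 2 `C/C(=C1/OC(=O)NC1=O)C(c1ccc(-c2ccc3cccc(F)c3c2)[nH]c1=O)C(C)C`: > 3 h, a limit of the assay and not a number

Compound 2 stands at the top of this short series: the limit of > 3 h in this assay, at which 1 of the 2 values shown sits. Among the compounds with values here, the only measured step at this place is an at least 5.1-fold higher number from compound 1 to compound 2 (0.71 log units; beyond the scatter), which lies beyond the scatter and shows that changing this group can move the half-life. Compound 3 `CC(C)C(/C=C1\SC(=O)NC1=O)c1ccc(-c2ccc3cccc(F)c3c2)[nH]c1=O` keeps the shared core and changes the same group: a group of 8 heavy atoms (4 carbon, 1 nitrogen, 2 oxygen, 1 sulfur; one five-membered non-aromatic ring with 2 hetero atoms) in place of a group of 9 heavy atoms (5 carbon, 1 nitrogen, 3 oxygen; one five-membered non-aromatic ring with 2 hetero atoms), on a saturated chain carbon bound to an aromatic carbon and a saturated chain carbon. Both groups are five-membered non-aromatic rings with 2 hetero atoms, so a smaller change than that measured step is expected, and with it a modest fall from the limit. The expected step is an at least 1.5-fold lower number from compound 2 to compound 3 (0.17 log units; that floor lies within the scatter), though its true size is uncertain with only a limit as the starting point. For compound 3 the estimate is 2 h, with an expected range from 0.7 h to 6 h.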

Compound 3, half-life: > 3 h
Compound 3: no number, only a limit; the forecaster's own chance of this, stated with the estimate: 40%; middle value at least 1.5-fold (0.17 log units) from the limit.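

In this assay compound 3 gives > 3 h, which is a limit of the assay and not a number. The group of 8 heavy atoms, which carries sulfur, gives an at least 5.1-fold higher number from compound 1 to compound 3 (0.71 log units; beyond the scatter), so a second group besides that of compound 2 now moves the half-life well away from the value of the group of 7 heavy atoms. The step between compound 2 and compound 3 cannot be read, and the two groups cannot be ranked, because both compounds stand at the same limit: the limit of > 3 h in this assay, at which 2 of the 3 values shown sit.

On these data alone, how long compound 2 and compound 3 actually last remains open. Also open, as far as these compounds go, is whether a group without a five-membered ring, such as a carboxylic acid or an amine on this saturated chain carbon, would keep the half-life at that limit.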